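The source may report more compounds than this note shows. Statements on the series, on what has been measured and on what is new or still open speak of the compounds shown alone.

Compound 1 `O=S(=O)(Nc1ccc(-c2nc3ccccc3o2)cc1)c1ccc(Cl)s1` is the only one of the three measured compounds that yields a number in an assay on cells for inhibition of HSP60/HSP10 (Homo sapiens), with a stated time of 60 min; a higher number here means a weaker inhibitor, a lower number a stronger inhibitor: compound 1 gives 31000 nM. Compound 2 `C=Cc1ccc(S(=O)(=O)Nc2ccc3oc(-c4ccccc4)nc3c2)cc1` gives > 100000 nM, which is a limit of the assay and not a number. Compound 3 `O=S(=O)(Nc1ccc2oc(-c3ccccc3)nc2c1)c1cccc(Cl)c1` likewise gives > 100000 nM, again a limit. Among the measured compounds shown here, compound 1 therefore stands as the single readable value, while the other two sit at the limit of > 100000 nM in this assay, at which 2 of the 3 values shown sit. For the measured compounds named here, the only step between measured compounds, a step that the two limits leave unreadable from compound 2 to compound 3, has both ends at a limit and yields no size. Compound 4 `O=S(=O)(Nc1ccc(-c2nc3ccccc3o2)cc1)c1cccs1` differs from compound 1 by hydrogen in place of chloro on an aromatic carbon. Going by the values given here, no measured step touches the thiophene ring, and the one step that does involve a chloro group is unreadable, so the data offer no direction for this change. The step of a 1.5-fold higher number from compound 1 to compound 4 (0.16 log units; within the scatter) is therefore expected to stay within the usual scatter, though a drift toward the limit cannot be excluded. The estimate for compound 4 is 45000 nM, expected to lie between 18000 nM and 110000 nM.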

Compound 4, half-maximal inhibitory concentration: 63000 nM
Beside the measured number, compound 4's estimate is 1.4-fold (0.15 log units) below it, within the range that was stated.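

Taking the chloro away from this aromatic carbon, next to the ring sulfur, gives the first readable step in this assay: a 2.0-fold higher number from compound 1 to compound 4 (0.31 log units; beyond the scatter). The chloro is thus not needed for a readable number, since compound 4 still gives one without it, but its loss leaves a modestly weaker inhibitor. Compound 1 and compound 4 are the only compounds shown with readable numbers, so this is the one change whose size can be stated, and the other values are limits: the limit of > 100000 nM in this assay, at which 2 of the 4 values shown sit.

Only chloro and hydrogen are shown at this place, so what a methyl group, a bromine or an amine would do there stays open. Also open, going by these compounds, is whether the same change would give a step of this size on a different core.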